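Methyl on the Ring Nitrogen of Compound 1

The source may report more compounds than this note shows. Statements on the series, on what has been measured and on what is new or still open speak of the compounds shown alone.

Among the three compounds measured in a functional assay on HeLa cells (Homo sapiens) for inhibition, read by MTT assay, with a stated time of 24 h (on this read-out higher numbers stand for weaker inhibition and lower numbers for stronger inhibition), compound 1 `CO/N=C1\C[C@@H](c2ccc(OC)cc2)N[C@@H](c2ccc(OC)cc2)[C@@H]1C` gives the highest number, 154000 nM. Compound 3 `CO/N=C1/[C@@H](C)[C@H](c2ccc(OC)cc2)N[C@H](c2ccc(OC)cc2)[C@H]1C` gives 93900 nM, which lies within the scatter of compound 1, while compound 2 `CO/N=C1/[C@@H](C)[C@H](c2cccc(F)c2)N[C@H](c2cccc(F)c2)[C@H]1C` gives 37900 nM, a number beyond the scatter. Compound 4 `CO/N=C1\C[C@@H](c2ccc(OC)cc2)N(C)[C@@H](c2ccc(OC)cc2)[C@@H]1C` differs from compound 1 by methyl in place of hydrogen on an amine nitrogen in a ring. Among the compounds with values here, the only single step measured, a 1.6-fold lower number from compound 1 to compound 3 (0.21 log units; within the scatter), concerns methyl on a saturated ring carbon, not on the amine nitrogen, and compound 2 differs from compound 1 in more than one place, so no measured step bears directly on this change. The expected step is therefore a 1.2-fold lower number from compound 1 to compound 4 (0.07 log units; within the scatter), within the scatter. Compound 4 is accordingly estimated at 130000 nM, between 45000 nM and 350000 nM.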

Compound 4, half-maximal inhibitory concentration: 80600 nM
The estimate for compound 4 lay 1.6-fold (0.21 log units) above the measured number; low and high end bracket the measured number.
By their numbers in this assay, from the lowest: compound 2; then compounds 4, 3 and 1 (each within the scatter of the next).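

With methyl in place of hydrogen on the amine nitrogen in the ring, this assay gives a 1.9-fold lower number from compound 1 to compound 4 (0.28 log units; within the scatter), so this nitrogen, next to two ring atoms that each bear a 4-methoxyphenyl group, takes a methyl without a step beyond the scatter. Until now, only methyl on a saturated ring carbon had been read, as a 1.6-fold lower number from compound 1 to compound 3 (0.21 log units; within the scatter). Nothing measured here explains the result. As far as these compounds go, whether an ethyl group, a longer chain or an acetyl group on this nitrogen would also stay within the scatter remains open, as does the same methyl change on the core of compound 2.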